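Diethylamino analogue of the oxamic acid series

This account rests on a few compounds, and the source may have more. Where it says the series, first, only, none or still open, it means among the compounds named here.

Measured compounds in a functional assay on the whole organism for inhibition, with Rattus norvegicus as the target, at a dose of 1 mg/kg by the oral route; on this read-out lower numbers stand for less inhibition and higher numbers for more inhibition at the one dose given (going by the name of the read-out):
compound 1 `CN(C)c1cccc(NC(=O)C(=O)O)c1C#N` gives 54.7%
compound 2 `CNc1cccc(NC(=O)C(=O)O)c1C#N` gives 96%
compound 3 `CCN(C)c1cccc(NC(=O)C(=O)O)c1C#N` gives 56.3%

Compound 3 stands second highest of the three numbers. Its nearest neighbour is compound 1, within the scatter (a number 1.6 percentage points higher from compound 1 to compound 3 (within the scatter)); its furthest is compound 2, beyond it (a number 39.7 percentage points lower from compound 2 to compound 3 (beyond the scatter)).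

Compound 4 `CCN(CC)c1cccc(NC(=O)C(=O)O)c1C#N` differs from compound 3 by methyl in place of hydrogen on a saturated chain carbon bound to a nitrogen on an aromatic ring. Going by the values given here, the one measured step of the same kind, a number 1.6 percentage points higher from compound 1 to compound 3 (within the scatter), lay within the scatter, so no step beyond the scatter is expected in this assay; the large steps of a number 41.3 percentage points higher from compound 1 to compound 2 (beyond the scatter) and a number 39.7 percentage points lower from compound 2 to compound 3 (beyond the scatter) concern a different change.

Compound 4 is therefore expected to give about 57%, between 42% and 72%, an expected step of a number 0.7 percentage points higher from compound 3 to compound 4 (within the scatter).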

Compound 4, a percentage reported as inhibition, in the whole organism at one dose (the size of the read-out at that dose, not a potency): 99.2%
Estimate against measurement, compound 4: 42.2 percentage points below, and the stated range ends below it.
By their numbers in this assay, from the lowest: compounds 1 and 3 (each within the scatter of the next); then compounds 2 and 4 (each within the scatter of the next).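

In this assay, the same added methyl that gave a number 1.6 percentage points higher from compound 1 to compound 3 (within the scatter) now gives a number 42.9 percentage points higher from compound 3 to compound 4 (beyond the scatter), so the outcome of this change depends on the chain already on the nitrogen. Diethylamino in place of dimethylamino gives a number 44.5 percentage points higher from compound 1 to compound 4 (beyond the scatter), whereas diethylamino in place of methylamino gives a number 3.2 percentage points higher from compound 2 to compound 4 (within the scatter), so the read-out does not follow chain size across the series. Nothing available explains this sharp turn.

From the compounds shown here alone, whether a propyl chain on that nitrogen holds the high number of the diethylamino compound remains open. So does the ranking of these compounds at other oral doses.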